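The source may hold more compounds than are shown below. What is called first, only, known or untested is meant among the compounds shown, and "the series" means these compounds.

Two close relatives of one core have been measured. Compound 1 `O=C(/C=C\Nc1ccc(F)cc1)c1cn(-c2ccccc2)nc1-c1ccccc1` carries a fluoro group on its outer aromatic ring, and in a functional assay on HT-29 cells (Homo sapiens) for antiproliferative activity, read by MTT assay, with a stated time of 48 h (on this read-out higher numbers stand for weaker inhibition and lower numbers for stronger inhibition), compound 1 gives 6870 nM. Compound 2 `O=C(/C=C\Nc1ccc(O)cc1)c1cn(-c2ccccc2)nc1-c1ccccc1` has a hydroxy group in the same place, and in this assay compound 2 gives 5000 nM. Within the data shown here, the single step between them, a 1.4-fold lower number from compound 1 to compound 2 (0.14 log units; within the scatter), is too small to separate the two, so compound 2 stands level with compound 1 rather than apart from it.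

Compound 3 `COc1ccc(N/C=C\C(=O)c2cn(-c3ccccc3)nc2-c2ccccc2)cc1` is the next relative: methyl in place of hydrogen on an oxygen on an aromatic ring. Among the measured compounds shown here, only one measured step touches this part of the molecule, and that step, a 1.4-fold lower number from compound 1 to compound 2 (0.14 log units; within the scatter), left the number essentially unchanged. With nothing else to draw on, the expectation for compound 3 is a step of no change at the digits printed from compound 2 to compound 3 (within the scatter), no larger than the scatter. The estimated value for compound 3 is therefore 5000 nM, with a range from 2000 nM to 12500 nM.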

Compound 3, half-maximal inhibitory concentration: 1560 nM
Compound 3: the middle estimate sits 3.2-fold (0.51 log units) above what was measured, outside the stated range (below it).
By their numbers in this assay, from the lowest: compound 3; then compounds 2 and 1 (each within the scatter of the next).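

Putting a methyl on the hydroxy oxygen gives a 3.2-fold lower number from compound 2 to compound 3 (0.51 log units; beyond the scatter) in this assay, so this position does respond to change, which the swap of fluoro for hydroxy could not show. Replacing fluoro with methoxy points the same way, with a 4.4-fold lower number from compound 1 to compound 3 (0.64 log units; beyond the scatter), which leaves compound 3 with the lowest number of the three and the other two level with each other. Nothing given here explains why the methoxy compound differs from the other two.

Going by these compounds, it remains open whether a longer chain on the same oxygen, such as ethoxy, would lower the number further or raise it again. It is also unknown how an amine or a carboxylic acid in place of the methoxy would compare.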